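Amide-side replacement on the shared core: cytotoxicity notes

The source may report more compounds than this note shows. Statements on the series, on what has been measured and on what is new or still open speak of the compounds shown alone.

Compound 1, `Cc1nc2cc(C(=O)NCc3ccc(F)cc3)nn2c(-c2cc(F)c3c(c2C)CCCO3)c1[C@H](OC(C)(C)C)C(=O)O`: in an ADME assay on MT2 cells (Homo sapiens) for cytotoxicity (a lower number here means that less compound is tolerated, a higher number that more compound is tolerated), compound 1 gives > 40000 nM, which is a limit of the assay.
Compound 2, `CNC(=O)c1cc(F)ccc1CNC(=O)c1cc2nc(C)c([C@H](OC(C)(C)C)C(=O)O)c(-c3cc(F)c4c(c3C)CCCO4)n2n1`: in this assay compound 2 gives > 40000 nM, also a limit.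

Compound 2 therefore stands at the limit, as summarised by the limit of > 40000 nM in this assay, at which 2 of the 2 values shown sit. Compound 3 is `CCCNC(=O)c1cc2nc(C)c([C@H](OC(C)(C)C)C(=O)O)c(-c3cc(F)c4c(c3C)CCCO4)n2n1`; it differs from compound 2 by ethyl in place of 4-fluoro-2-(methylcarbamoyl)phenyl on a saturated chain carbon bound to an amide-type nitrogen. Among the compounds with values here, the one measured step in this region, a step that the two limits leave unreadable from compound 1 to compound 2, has a size that cannot be read, so no measured step sets a magnitude. Compound 3 is therefore expected to stay at the limit in this assay, and the expected step that the limit leaves unreadable from compound 2 to compound 3 is none beyond the scatter. For compound 3 the estimate is 50000 nM, range 25000 nM to 100000 nM.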

Compound 3, half-maximal cytotoxic concentration: > 40000 nM
Compound 3: a limit, no number; the forecaster's own chance of this, stated with the estimate: 80%; the middle value lies beyond the limit too.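

Compound 1, compound 2 and compound 3 all sit at a limit in this assay, so no step among them can be read: the limit of > 40000 nM in this assay, at which 3 of the 3 values shown sit.

The compounds shown leave open where the actual half-maximal cytotoxic concentration of each lies, and whether any amide-side replacement on the shared core changes it.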